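A few compounds are considered here, and "the series" means these few. Any claim that something is new, unique, unknown or untested is made for them only; others in the source may bear on it.

Measured in a functional assay on A549 cells (Homo sapiens) for antiproliferative activity, read by MTT assay, with a stated time of 24 h; a lower number here means a stronger inhibitor, a higher number a weaker inhibitor:
compound 1, `Cc1ccccc1-n1cc(-c2cccc(NS(=O)(=O)c3c[nH]c(=O)[nH]c3=O)c2)nn1`: 5470 nM
compound 2, `Cc1cccc(-n2cc(-c3cccc(NS(=O)(=O)c4c[nH]c(=O)[nH]c4=O)c3)nn2)c1`: 3550 nM
compound 3, `Cc1ccccc1-n1cc(-c2ccc(NS(=O)(=O)c3c[nH]c(=O)[nH]c3=O)cc2)nn1`: 3130 nM

Compound 1 and compound 2 share a core and differ in one place, the change being (3-methylphenyl in place of 2-methylphenyl on an aromatic nitrogen). The step it made, a 1.5-fold lower number from compound 1 to compound 2 (0.19 log units; within the scatter), is within the scatter, so the two values are read as alike rather than as a gain. Compound 3 differs from compound 1 in its core; the difference between the two cores is not broken down here. The values of compound 3 and compound 2 lie within the scatter of each other, as do those of compound 3 and compound 1, so no order among the three measured compounds is claimed.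

Compound 4, `Cc1cccc(-n2cc(-c3ccc(NS(=O)(=O)c4c[nH]c(=O)[nH]c4=O)cc3)nn2)c1`, is not yet measured. It relates to compound 3 as compound 2 relates to compound 1: the change is 3-methylphenyl in place of 2-methylphenyl on an aromatic nitrogen, and the place is described in the same words, so it is the same change made on the core of compound 3. Only one earlier occurrence of the change is known, and its step was a 1.5-fold lower number from compound 1 to compound 2 (0.19 log units; within the scatter). With a single pair to draw on and a step that itself sits within the scatter, the expectation is held loosely. For compound 4 a step of similar size is expected in this assay, a 1.4-fold lower number from compound 3 to compound 4 (0.13 log units; within the scatter), the same direction as the earlier pair but with wide bounds. Compound 4 is therefore estimated at 2300 nM, with a range from 1100 nM to 5000 nM.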

Compound 4, half-maximal inhibitory concentration: 6960 nM
Compound 4: middle estimate off by 3.0-fold (0.48 log units), on the low side, and the stated range ends below it.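

In this assay, placing 3-methylphenyl instead of 2-methylphenyl on the aromatic nitrogen gives a 2.2-fold higher number from compound 3 to compound 4 (0.35 log units; beyond the scatter), so the change does not carry from one core to the other as a single fixed step: the same change on two cores in this assay, a 1.5-fold lower number (0.19 log units; within the scatter) from compound 1 to compound 2 and a 2.2-fold higher number (0.35 log units; beyond the scatter) from compound 3 to compound 4, 3.4-fold (0.53 log units) apart, beyond the scatter of two such steps

Within these two pairs, the outcome of the change therefore depends on the core that carries it, and a step read on the core of compound 1 is a poor guide to the step on the core of compound 3. For the compounds shown here, this does not establish a true reversal of direction, as only the step on the core of compound 3 lies beyond the scatter, and with a 1.5-fold lower number from compound 1 to compound 2 (0.19 log units; within the scatter) compound 1 and compound 2 are read as alike; two pairs also give no general rule for the series and no explanation for the gap between the steps.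

On these data alone, it remains open whether the same dependence on the core appears with other groups on that aromatic nitrogen, such as plain phenyl, ethylphenyl or a phenyl bearing an amine or a carboxylic acid. As far as these compounds go, it is also open whether the gap between the two steps would persist in a read-out other than this assay.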